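The source may hold more compounds than are shown below. What is called first, only, known or untested is meant among the compounds shown, and "the series" means these compounds.

Compound 2 `O=C(Nc1cccc(-c2nc3ccccc3s2)c1)c1cc([N+](=O)[O-])ccc1Cl` and compound 1 `O=C(Nc1ccc(F)c(-c2nc3ccccc3s2)c1)c1cc([N+](=O)[O-])ccc1Cl` share a core and differ by fluoro in place of hydrogen on an aromatic carbon. In an ADME assay on BJ cells (Homo sapiens) for cytotoxicity, with a stated time of 72 h (on this read-out lower numbers stand for an effect already at smaller amounts and higher numbers for an effect only at larger amounts of compound), compound 2 gives > 27000 nM, which is a limit of the assay rather than a number. Compound 1 gives > 25000 nM, again a limit. The step between them reads a step that the two limits leave unreadable from compound 2 to compound 1. Compound 3 `O=C(Nc1nc(-c2cccc(F)c2)cs1)c1cc([N+](=O)[O-])ccc1Cl` is built on another core; the difference between the two cores is not broken down here. In this assay, within the data shown here, compound 3 gives 24000 nM, the only plain number of the three. Compound 4 `O=C(Nc1nc(-c2ccc(F)c(F)c2)cs1)c1cc([N+](=O)[O-])ccc1Cl` differs from compound 3 by fluoro in place of hydrogen on an aromatic carbon. This is the same kind of change as from compound 2 to compound 1, but here the entering fluoro sits ortho to a fluoro group rather than ortho to a 1,3-benzothiazol-2-yl group. In this assay the step is expected to be a 1.0-fold higher number from compound 3 to compound 4 (0.02 log units; within the scatter), resting on compound 3 at 24000 nM and on the earlier step being unreadable. Compound 4 is estimated at 25000 nM, between 12000 nM and 50000 nM.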

Compound 4, half-maximal effective concentration: > 27000 nM
Compound 4 was reported as a limit (the forecaster's own chance of this, stated with the estimate: 50%); at least 1.0-fold (0.03 log units) between middle value and limit.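

In this assay the step on the core of compound 3 reads an at least 1.1-fold higher number from compound 3 to compound 4 (0.05 log units; that floor lies within the scatter) and that floor alone shows no change beyond the usual scatter. From the compounds shown here alone, compound 4 gives > 27000 nM as a limit of the assay, so the true size of the step stays open: the limit of > 27000 nM in this assay, at which 2 of the 4 values shown sit. The step for the same change on the core of compound 2 cannot be read, which leaves the two cores without a comparison and shows neither that the change carries over nor that it fails to.

The compounds shown carry only hydrogen or fluoro at the changed place. Going by these compounds, what a methoxy group, an amine or a carboxylic acid would do there remains open.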